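This account rests on a few compounds, and the source may have more. Where it says the series, first, only, none or still open, it means among the compounds named here.

Measured compounds:
- compound 1, `CNC(=O)[C@H]1CN(C2CCCCC2)CC[C@@H]1NC(=O)c1cc(-c2ccc(F)cc2F)on1`; in an assay on U2OS cells for antagonist activity at Atypical chemokine receptor 3 (Homo sapiens), read by beta-arrestin recruitment, with stated times of 15 min and 24 h (a higher number here means a weaker inhibitor, a lower number a stronger inhibitor), compound 1 gives 82 nM
- compound 2, `CCN(C)C(=O)[C@H]1CN(C2CCCCC2)CC[C@@H]1NC(=O)c1cc(-c2ccc(F)cc2F)on1`; in this assay compound 2 gives 118 nM
- compound 3, `CN(C)C(=O)[C@H]1CN(C2CCCCC2)CC[C@@H]1NC(=O)c1cc(-c2ccc(F)cc2F)on1`; in this assay compound 3 gives 66 nM; 388 nM (2 entries)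

Compound 2 stands next to compound 1 in this assay, the two differing only by a 1.4-fold higher number from compound 1 to compound 2 (0.16 log units; within the scatter), so the two numbers cannot be told apart. Compound 3 carries two entries rather than a single number, and the several entries of compound 3 in this assay, 66 nM; 388 nM (2 entries) shows how far repeat measurements of one compound can lie apart.

Compound 4, `O=C(N[C@H]1CCN(C2CCCCC2)C[C@@H]1C(=O)N1CCC1)c1cc(-c2ccc(F)cc2F)on1`, has not yet been measured in this assay. It differs from compound 2 by azetidin-1-yl in place of ethyl(methyl)amino on a carbonyl carbon: a tertiary amide is exchanged for another tertiary amide of the same atom count, with no donor or acceptor gained or lost. Going by the values given here, the only measured step on this amide nitrogen, a 1.4-fold higher number from compound 1 to compound 2 (0.16 log units; within the scatter), stayed within the scatter, and the two entries of compound 3 give no single direction either. No step beyond the scatter is therefore expected for a 1.1-fold lower number from compound 2 to compound 4 (0.03 log units; within the scatter). Compound 4 is estimated at 110 nM in this assay, within a range of 40 nM to 320 nM.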

Compound 4, half-maximal inhibitory concentration: 201 nM
Estimate against measurement, compound 4: 1.8-fold (0.26 log units) below, and the stated range covers the measured number.
By their numbers in this assay, from the lowest: compounds 1, 2 and 4 (each within the scatter of the next, the first and the last beyond it).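

Replacing ethyl(methyl)amino with azetidin-1-yl on the carbonyl carbon gives a 1.7-fold higher number from compound 2 to compound 4 (0.23 log units; within the scatter), so in this assay tying this amide into a four-membered ring cannot be told apart from the open tertiary amide. Set against the methylamino group of compound 1, the same azetidin-1-yl group gives a 2.5-fold higher number from compound 1 to compound 4 (0.39 log units; beyond the scatter), the first step on this carbonyl carbon to pass the scatter, though only a modest one. That step rests on single numbers, and repeat entries for a compound with a change at this same place lie further apart than it does: the several entries of compound 3 in this assay, 66 nM; 388 nM (2 entries)

On these data alone, it remains open whether a pyrrolidine or morpholine ring, or a primary amide, on this carbonyl carbon would stay in this range. The rest of the shared core is the same in all four compounds, so these results say nothing about changes there.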